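The source may report more compounds than this note shows. Statements on the series, on what has been measured and on what is new or still open speak of the compounds shown alone.

In a functional assay on PC-3 cells (Homo sapiens) for inhibition, read by sulforhodamine B assay, with a stated time of 48 h (on this read-out lower numbers stand for stronger inhibition of growth and higher numbers for weaker inhibition of growth), compounds built on a shared core have so far given almost nothing but limits. Compound 1 `CCOC(=O)c1nn(-c2ccc(Cl)cc2)c(-c2ccc(F)cc2)c1CNC(C)(C)C` gives 405000 nM; > 537000 nM (2 entries) across its entries. Compound 2 `CC(C)(C)NCc1c(C(=O)O)nn(-c2ccccc2)c1-c1ccc(Br)cc1` gives > 585000 nM, which is a limit. Compound 3 `CC(C)(C)NCc1c(C(=O)O)nn(-c2ccc(Cl)cc2)c1-c1ccc(F)cc1` gives > 623000 nM, and this too is only a limit, so it stands without an exact number.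

Compound 4 `CC(C)(C)NCc1c(C(=O)O)nn(-c2ccc(Cl)cc2)c1-c1ccc(Br)cc1` differs from compound 3 by bromo in place of fluoro on an aromatic carbon, turning the 4-fluorophenyl into a 4-bromophenyl. No measured step between any of these compounds is available to guide the estimate. The expectation leans on compound 2, which also carries a 4-bromophenyl and shows > 585000 nM, a limit. No change beyond the usual scatter is expected in this assay, and the estimated step is an at least 1.1-fold lower number from compound 3 to compound 4 (0.06 log units; that floor lies within the scatter). Compound 4 is likely to be reported only as a limit. For compound 4 the estimated value is 540000 nM, with an expected range from 300000 nM to 800000 nM.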

Compound 4, concentration for 50% growth inhibition: > 542000 nM
Compound 4 ended at the assay's limit; the forecaster's own chance of this, stated with the estimate: 80%; middle value at least 1.0-fold (0.00 log units) from the limit.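

Compound 2, compound 3 and compound 4 are each reported in this assay only as limits, so neither the step from compound 3 to compound 4 nor the step from compound 2 to compound 4 can be read. The compounds shown leave open whether bromo in place of fluoro, or chloro in place of hydrogen, changes growth inhibition at all.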